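A few compounds are considered here, and "the series" means these few. Any claim that something is new, unique, unknown or untested is made for them only; others in the source may bear on it.

Working notes on the series. Compound 1 `CN1CCN(CC(=O)Nc2ccc(-c3nc4cc(C(F)(F)F)ccc4n3C)cc2)CC1` gives 44000 nM in an ADME assay on MDBK cells (Bos taurus) for cytotoxicity, read by MTT assay, with a stated time of 96 h; a lower number here means that less compound is tolerated, a higher number that more compound is tolerated. Compound 2 `CC(=O)Nc1ccc(-c2nc3cc(C(F)(F)F)ccc3n2C)cc1` gives 46000 nM in this assay; on the two numbers shown it stands together with compound 1, since the step of a 1.0-fold higher number from compound 1 to compound 2 (0.02 log units; within the scatter) is within the scatter. Compound 3 `Cn1c(-c2ccc(N)cc2)nc2cc(C(F)(F)F)ccc21` has not yet been measured in this assay. Its change from compound 2 is hydrogen in place of acetyl on a nitrogen on an aromatic ring. Within the data shown here, the only measured step, a 1.0-fold higher number from compound 1 to compound 2 (0.02 log units; within the scatter), concerns a different place, the saturated chain carbon bound to the carbonyl carbon, and moved the number not at all; no measured pair alters the nitrogen on the aromatic ring itself, so that single step is the only guide and it argues for little movement. The expected step of a 1.2-fold lower number from compound 2 to compound 3 (0.06 log units; within the scatter) is therefore small, with no direction expected to show beyond the scatter. For compound 3 the estimate in this assay is 40000 nM, with a range from 15000 nM to 100000 nM.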

Compound 3, half-maximal cytotoxic concentration: 74000 nM
The estimate for compound 3 lay 1.9-fold (0.27 log units) below the measured number, within the range that was stated.
By their numbers in this assay, from the lowest: compounds 1, 2 and 3 (each within the scatter of the next).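

In this assay, among these compounds, the change acetamido to amino on the nitrogen on an aromatic ring gives a 1.6-fold higher number from compound 2 to compound 3 (0.21 log units; within the scatter) and is the first measured change at this nitrogen itself. Taking the whole ((4-methylpiperazin-1-yl)methyl)carbonyl off the same nitrogen gives a 1.7-fold higher number from compound 1 to compound 3 (0.23 log units; within the scatter) and so also leaves the number within the scatter, which means that the free amino compound cannot be separated from either acylated compound in this assay. No supporting measurement bears on why these numbers stay together.

Going by these compounds, how a methyl or a methanesulfonyl group on this nitrogen would read remains open, as does a longer chain ending in a carboxylic acid. On these data alone, all three compounds also share the trifluoromethyl group and the core, so a nitrile in place of the trifluoromethyl group remains untested here.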